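The source may report more compounds than this note shows. Statements on the series, on what has been measured and on what is new or still open speak of the compounds shown alone.

Measured so far in a functional assay on DLD-1 cells (Homo sapiens) for antiproliferative activity, read by trypan blue exclusion; a higher number here means a weaker inhibitor, a lower number a stronger inhibitor:

compound 1 `COc1cc(OC)c(/C=C/S(=O)(=O)Cc2cc(OC)c(OC)c(OC)c2)c(OC)c1`: reported as a limit only, > 20000 nM
compound 2 `COc1cc(OC)c(/C=C/S(=O)(=O)Cc2ccc(OC)c(OC)c2OC)c(OC)c1`: 15000 nM
compound 3 `COc1cc(OC)c(/C=C/S(=O)(=O)Cc2ccc(Cl)cc2)c(OC)c1`: 15000 nM

Compound 3 stands level with compound 2 at the digits shown; the two values lie within the scatter of each other, so no order between them can be read. Of compound 1 only a limit is known (the limit of > 20000 nM in this assay, at which 1 of the 3 values shown sits). Among the measured compounds shown here, both numbers that were obtained sit in the weak range, and no measured pair in the set differs in a single place, so no step size has been observed for any single change.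

Compound 4 `COc1cc(OC)c(/C=C/S(=O)(=O)Cc2ccc(OC(F)(F)F)cc2)c(OC)c1` is the next member, differing from compound 3 by trifluoromethoxy in place of chloro on an aromatic carbon. For the measured compounds named here, with no measured step to lean on, the expectation for this change is a step of no more than the scatter in either direction, no change at the digits printed from compound 3 to compound 4 (within the scatter). Compound 4 is accordingly estimated at 15000 nM, with a range from 6000 nM to 35000 nM, the upper end of which reaches the region where this assay reports a limit rather than a number.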

Compound 4, half-maximal inhibitory concentration: 4000 nM
Estimate against measurement, compound 4: 3.8-fold (0.57 log units) above; measured number outside the range, below it.
By their numbers in this assay, from the lowest: compound 4; then compounds 2 and 3 (each within the scatter of the next). At a limit, above all of these: compound 1.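

In this assay, among the compounds shown here, trifluoromethoxy in place of chloro on an aromatic carbon, para to a large group, gives a 3.8-fold lower number from compound 3 to compound 4 (0.57 log units; beyond the scatter), the only single-place step so far. For the compounds shown here, this shows that the number responds to the group at this position, which the earlier compounds could not show. It also shows that the position accepts the entry of 5 heavy atoms for the 1 that leaves without the number rising. Nothing measured here gives a reason for this step.

One step cannot tell whether a trifluoromethyl, a nitrile, an amine or a carboxylic acid at this position would follow compound 4. Steps involving compound 1 or compound 2 cannot be read, as neither differs from another compound in only one place.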